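Cytotoxicity notes: chlorophenyl in place of furan on the ester

The source may hold more compounds than are shown below. What is called first, only, known or untested is meant among the compounds shown, and "the series" means these compounds.

Measured compounds:
- Compound 1 `CC(C)N(Cc1cccc(OCCCCCC(=O)O)c1)C(=O)c1ccc(-c2ccco2)cc1` gives > 26000 nM in an ADME assay on BJ cells (Homo sapiens) for cytotoxicity, read by CellTiter-Glo and resazurin assay, with a stated time of 72 h; on this read-out higher numbers stand for an effect only at larger amounts of compound and lower numbers for an effect already at smaller amounts; this is a limit of the assay.
- Compound 2 `Cc1nnc(-c2cccc(-c3ccc(C(=O)N(Cc4cccc(OCCCCCC(=O)O)c4)C(C)C)cc3)c2)o1` gives > 26000 nM in this assay; again a limit.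
- Compound 3 `CCOC(=O)CCCCCOc1cccc(CN(C(=O)c2ccc(-c3ccco3)cc2)C(C)C)c1` gives > 26000 nM in this assay; again a limit.

Compound 3 stands at the limit of > 26000 nM in this assay, at which 3 of the 3 values shown sit, so it has no number of its own, only a limit. The steps a step that the two limits leave unreadable from compound 1 to compound 3 and a step that the two limits leave unreadable from compound 1 to compound 2 are both unreadable, since each joins two limits. Compound 4 `CCOC(=O)CCCCCOc1cccc(CN(C(=O)c2ccc(-c3cccc(Cl)c3)cc2)C(C)C)c1` carries the change (3-chlorophenyl in place of furan-2-yl on an aromatic carbon). Among the measured compounds shown here, no measured step bears on this change, and no measured compound in this assay has given a number rather than a limit. Compound 4 is therefore expected to remain at the limit, with a step that the limit leaves unreadable from compound 3 to compound 4 as the estimated step. The estimate for compound 4 is 40000 nM, ranging from 15000 nM to 150000 nM.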

Compound 4, half-maximal effective concentration: > 18400 nM
Compound 4: no number, only a limit; the forecaster's own chance of this, stated with the estimate: 80%; the middle value lies beyond the limit too.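

In this assay compound 3 gives > 26000 nM, a limit. Among the compounds shown here, compound 4 gives > 18400 nM, also a limit, so no step between compound 3 and compound 4 can be read. The compounds shown leave open at what concentration any of them would show cytotoxicity.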